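The compounds below may be only part of what the source reports. "The series", "measured", "known", "first", "only" and "open" are said of these compounds alone.

Measured in a functional assay on KB cells (Homo sapiens) for cytotoxicity; on this read-out higher numbers stand for weaker inhibition and lower numbers for stronger inhibition:
- compound 1 `COc1ccc(S(=O)(=O)N2CCc3cccc(NS(=O)(=O)c4ccc(F)cc4)c32)cc1`: 1200 nM
- compound 2 `COc1ccc(S(=O)(=O)N2CCc3cccc(NS(=O)(=O)c4ccccc4)c32)cc1`: 650 nM

Compound 2, at 650 nM, lies within the scatter of compound 1, so the two cannot be ranked. Compound 3 `COc1ccc(S(=O)(=O)N2CCc3cccc(NS(=O)(=O)c4ccc([N+](=O)[O-])cc4)c32)cc1` carries nitro in place of hydrogen on an aromatic carbon, para to a large group (nitro in place of hydrogen on an aromatic carbon). Among the measured compounds shown here, the one measured step that bears on this is a 1.8-fold lower number from compound 1 to compound 2 (0.27 log units; within the scatter), hydrogen in place of fluoro, and it stays within the scatter. It is thin evidence for nitro, so no clear change is expected in this assay. The expected step is a 1.2-fold higher number from compound 2 to compound 3 (0.09 log units; within the scatter), no larger than the scatter. For compound 3 the estimated value is 800 nM, with an expected range of 250 nM to 2500 nM.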

Compound 3, half-maximal inhibitory concentration: 1100 nM
Estimate against measurement, compound 3: 1.4-fold (0.14 log units) below; low and high end bracket the measured number.
By their numbers in this assay, from the lowest: compounds 2, 3 and 1 (each within the scatter of the next).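

In this assay nitro in place of hydrogen gives a 1.7-fold higher number from compound 2 to compound 3 (0.23 log units; within the scatter) and nitro in place of fluoro gives a 1.1-fold lower number from compound 1 to compound 3 (0.04 log units; within the scatter) so both steps stay within the scatter. Hydrogen, fluoro and nitro at this place, para to a large group, therefore cannot be ranked, and this now holds for a group of 3 heavy atoms as well as for a single fluoro atom. No supporting measurement offers an explanation for this result. Going by these compounds, whether an amine or a carboxylic acid at the same place would move the number beyond the scatter remains open.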